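Capping the hydroxy group of compound 3 as a methyl ether

The source may report more compounds than this note shows. Statements on the series, on what has been measured and on what is new or still open speak of the compounds shown alone.

Three compounds have a reading in a functional assay, read by spectrophotometry, with a stated time of 30 min (on this read-out lower numbers stand for an effect already at smaller amounts and higher numbers for an effect only at larger amounts of compound), so far. There compound 1 `COc1cc(/C=C/C2=CC(=O)CC(c3ccc(O)c(OC)c3)N2CCCO)ccc1O` gives 33900 nM as a measured number, and compound 3 `O=C(/C=C(/C=C/c1ccc(O)cc1)NCCCO)/C=C/c1ccc(O)cc1` gives 154000 nM as a measured number. Compound 2 `COCCCN1C(/C=C/c2ccc(O)cc2)=CC(=O)CC1c1ccc(O)cc1` gives > 200000 nM as a limit of the assay and not as a number. Compound 3 thus holds the higher of the two actual numbers, and its gap to compound 1 lies beyond the scatter.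

The compound now in question, compound 4 `COCCCNC(=C\C(=O)/C=C/c1ccc(O)cc1)/C=C/c1ccc(O)cc1` differs from compound 3 by a single change (methyl in place of hydrogen on an oxygen on a saturated carbon) that takes hydroxy to methoxy. Among the measured compounds shown here, no measured pair shows this change alone, so its size in this assay cannot be read from any step. For the measured compounds named here, the only hint is that compound 2, which also bears a methoxy group, gives > 200000 nM as a limit. A small move toward a higher number is therefore expected, quite possibly within the scatter, and a result reported only as a limit would be no surprise. The expected change is a 1.1-fold higher number from compound 3 to compound 4 (0.04 log units; within the scatter) and no larger shift is anticipated. Compound 4 is estimated at 170000 nM with an expected range from 90000 nM to 200000 nM if a number is returned at all.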

Compound 4, half-maximal effective concentration: 130000 nM
Compound 4: the middle estimate sits 1.3-fold (0.12 log units) above what was measured; the measured number falls inside the stated range.
By their numbers in this assay, from the lowest: compound 1; then compounds 4 and 3 (each within the scatter of the next). At a limit, above all of these: compound 2.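

In this assay, among the compounds shown here, the change from hydroxy to methoxy can now be read on its own for the first time, as methyl in place of hydrogen on an oxygen on a saturated carbon: a 1.2-fold lower number from compound 3 to compound 4 (0.07 log units; within the scatter). This step lies within the scatter, so in this one pair the hydrogen on that oxygen can be replaced by methyl without a measurable change in the reading. Compound 2 also carries a methoxy group, but its reading is a limit and not a number, so it offers no second measure of this change: the limit of > 200000 nM in this assay, at which 1 of the 4 values shown sits.

The compounds shown leave open whether a larger group on this oxygen, such as ethyl or benzyl, or an amine or a carboxylic acid in place of the hydroxy group, would move the number beyond the scatter. For the compounds shown here, they also leave open whether the same change from hydroxy to methoxy would stay within the scatter on the core of compound 1, which gives the lowest number so far in this assay.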